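The source may hold more compounds than are shown below. What is called first, only, known or untested is meant among the compounds shown, and "the series" means these compounds.

Measured so far in a functional assay on MDA-MB-231 cells (Homo sapiens) for cytotoxicity, read by MTT assay, with a stated time of 48 h; a lower number here means a stronger inhibitor, a higher number a weaker inhibitor:
- compound 1 `O=C(NCCCCC(c1ccc(F)cc1)c1ccc(F)cc1)Nc1ccc(I)cc1`: 11800 nM
- compound 2 `O=C(NCCCCC(c1ccc(F)cc1)c1ccc(F)cc1)Nc1ccc(C(F)(F)F)cc1`: 2780 nM
- compound 3 `Cc1ccc(NC(=O)NCCCCC(c2ccc(F)cc2)c2ccc(F)cc2)cc1C`: > 20000 nM, a limit

Compound 3 has no number on this assay, only the limit > 20000 nM. Moving to compound 4 `O=C(NCCCCC(c1ccc(F)cc1)c1ccc(F)cc1)c1ccc(Cl)c(C(F)(F)F)c1` brings (4-chloro-3-(trifluoromethyl)phenyl in place of (3,4-dimethylphenyl)amino on a carbonyl carbon), with 4-chloro-3-(trifluoromethyl)phenyl in place of (3,4-dimethylphenyl)amino on a carbonyl carbon.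

Going by the values given here, two measured steps bear on this most directly: an at least 7.1-fold higher number from compound 2 to compound 3 (0.85 log units; beyond the scatter) and a 4.2-fold lower number from compound 1 to compound 2 (0.63 log units; beyond the scatter). The floor in an at least 1.6-fold higher number from compound 1 to compound 3 (0.22 log units; that floor lies within the scatter) adds little. Among the compounds with values here, none of these steps removes the amino link on the carbonyl carbon, and no measured compound carries the chloro group, so any transfer is uncertain.

A modest step to a lower number is still expected on this assay. This expectation rests on compound 2 at 2780 nM, which also carries trifluoromethyl on its ring. The expected change is an at least 4.0-fold lower number from compound 3 to compound 4 (0.60 log units; beyond the scatter). For compound 4 the estimate is 5000 nM. The expected range for compound 4 runs from 1800 nM to 16000 nM.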

Compound 4, half-maximal inhibitory concentration: 11700 nM
Estimate against measurement, compound 4: 2.3-fold (0.37 log units) below; the measured number falls inside the stated range.
By their numbers in this assay, from the lowest: compound 2; then compounds 4 and 1 (each within the scatter of the next). At a limit, above all of these: compound 3.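

Removing the amino link on the carbonyl carbon does not push the read-out in this assay to the limit, and the number stays level with the 4-iodophenyl compound: a 1.0-fold lower number from compound 1 to compound 4 (0.00 log units; within the scatter). Trifluoromethyl on the ring does not by itself keep the lower number, as the change to 4-chloro-3-(trifluoromethyl)phenyl gives a 4.2-fold higher number from compound 2 to compound 4 (0.62 log units; beyond the scatter). Against the 3,4-dimethylphenyl compound only a floor can be read, an at least 1.7-fold lower number from compound 3 to compound 4 (0.23 log units; that floor lies within the scatter), and it rests on a limit: the limit of > 20000 nM in this assay, at which 1 of the 4 values shown sits.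

The compounds shown do not separate the loss of the amino link from the arrival of the chloro group; the change brings both at once. As far as these compounds go, how a nitrile on the ring, or a methylene link in place of the amino link, would read in this assay remains open.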